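This account rests on a few compounds, and the source may have more. Where it says the series, first, only, none or still open, it means among the compounds named here.

For the measured compounds named here, in an ADME assay on BJ cells (Homo sapiens) for cytotoxicity, with a stated time of 72 h (a lower number here means that less compound is needed, a higher number that more compound is needed for the effect), the three compounds measured so far all return the same limit rather than a number. Compound 1 `Cc1cc(NC(=O)Nc2ccc([N+](=O)[O-])c(C(F)(F)F)c2)c2ccccc2n1` reaches only the limit of > 25000 nM. Compound 2 `Cc1cc(NC(=O)Nc2ncccc2C)c2ccccc2n1` likewise gives only the limit of > 25000 nM. Compound 3 `Cc1cc(NC(=O)Nc2cccc(C(N)=O)c2)c2ccccc2n1` also stops at the limit of > 25000 nM. Compound 2 thus stands exactly where the other two measured compounds stand, at the limit of > 25000 nM in this assay, at which 3 of the 3 values shown sit, and no measured number sets it apart from them. Compound 4 `Cc1cc(NC(=O)Nc2ccc(O)cc2)c2ccccc2n1` has not yet been tested. It keeps the shared core of compound 2 and differs from it in a single place: 4-hydroxyphenyl in place of 3-methylpyridin-2-yl on an amide-type nitrogen. Going by the values given here, no pair of measured compounds shows what such a change does, so the expectation can rest only on the three limits. The expected step from compound 2 to compound 4 is a step that the limit leaves unreadable from compound 2 to compound 4, that is, none beyond the usual scatter, because all three measured compounds sit at the limit of > 25000 nM in this assay, at which 3 of the 3 values shown sit. Compound 4 is therefore expected to give about 30000 nM, within a range from 15000 nM to 80000 nM, most likely reported again only as a limit.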

Compound 4, half-maximal effective concentration: > 25000 nM
Compound 4: only a limit was reported (the forecaster's own chance of this, stated with the estimate: 85%); the middle value lies beyond the limit too.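

Compound 2 and compound 4 each return only a limit, not a number, so no step between them can be read: the limit of > 25000 nM in this assay, at which 4 of the 4 values shown sit.

The compounds shown leave open what 4-hydroxyphenyl in place of 3-methylpyridin-2-yl actually does here, and whether any compound with the shared core would give a true number.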